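A few compounds are considered here, and "the series" means these few. Any claim that something is new, unique, unknown or untested is made for them only; others in the source may bear on it.

Compound 3, `Cc1cc(C)cc(C(=O)N(NC(=O)c2ccccc2)C(C)(C)C)c1`, is the compound with the lowest number among the three measured. In an assay on cells for agonist activity at ecdysone receptor (Bombyx mori), read by a luciferase reporter, with a stated time of 24 h (a higher number here means that more compound is needed for the effect, a lower number that less compound is needed), compound 3 gives 69.2 nM. Its nearest neighbour is compound 1, `CC(C)(C)N(NC(=O)c1ccccc1)C(=O)c1ccccc1I`, which in this assay gives 105 nM; the step of a 1.5-fold lower number from compound 1 to compound 3 (0.18 log units; within the scatter) lies within the scatter, so the two cannot be ranked. The furthest is compound 2, `COc1ccccc1C(=O)N(NC(=O)c1ccccc1)C(C)(C)C`, which gives 525 nM; here the step of a 7.6-fold lower number from compound 2 to compound 3 (0.88 log units; beyond the scatter) is beyond the scatter, as is a 5.0-fold higher number from compound 1 to compound 2 (0.70 log units; beyond the scatter).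

Compound 4, `Cc1cc(C)cc(C(=O)N(NC(=O)CCC(C)C)C(C)(C)C)c1`, differs from compound 3 in one place: isopentyl in place of phenyl on a carbonyl carbon. Every measured step changes the substituent pattern of the aromatic ring on the other carbonyl; none replaces an aromatic ring with a chain, and none touches this carbonyl at all. The measured steps therefore give no direct guide, and the expectation rests on the change itself, which removes one of the two aromatic rings that all three measured compounds share. The number is expected to rise, and a step of a 29-fold higher number from compound 3 to compound 4 (1.46 log units; beyond the scatter) is estimated, with a wide range reflecting the lack of a matching precedent. For compound 4 the estimate in this assay is 2000 nM, between 300 nM and 15000 nM.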

Compound 4, half-maximal effective concentration: 91.2 nM
For compound 4 the middle estimate is 22-fold (1.34 log units) above the measured one, outside the stated range (below it).
By their numbers in this assay, from the lowest: compounds 3, 4 and 1 (each within the scatter of the next); then compound 2.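

In this assay the phenyl on this carbonyl carbon proves replaceable: exchanging it for isopentyl gives a 1.3-fold higher number from compound 3 to compound 4 (0.12 log units; within the scatter) and so no change that can be told from scatter. Going by these compounds alone, this is the first view of this carbonyl, and it shows that an open chain with no ring can stand where all the earlier compounds carried an aromatic ring. The earlier compounds shown here varied only the aromatic ring on the other carbonyl, where a single exchange gave a 7.6-fold lower number from compound 2 to compound 3 (0.88 log units; beyond the scatter) and thus moved the number beyond the scatter, whereas this much larger change in ring count leaves it level. The compounds shown give no information that could explain this tolerance.

From the compounds shown here alone, the isopentyl group is seen here only together with 3,5-dimethylphenyl on the other carbonyl, so it remains open whether it would behave the same way alongside 2-iodophenyl or 2-methoxyphenyl. Going by these compounds, it also remains open how far this carbonyl carbon accepts other groups, such as a shorter ethyl chain, a longer octyl chain, a cyclohexyl ring, or a chain ending in an amine or a carboxylic acid.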